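The source may report more compounds than this note shows. Statements on the series, on what has been measured and on what is new or still open speak of the compounds shown alone.

Compound 1 `Cc1cc(=O)c2c(O)cc(O)c([C@H]3CCN(C)C[C@H]3OC(=O)c3ccco3)c2o1`: 13%
Compound 2 `CCN(CC)Cc1c(O)c([C@H]2CCN(C)C[C@H]2O)c2oc(C)cc(=O)c2c1O`: 27%
Compound 3 `Cc1cc(=O)c2c(O)c(CN3CCC(c4ccccc4)CC3)c(O)c([C@H]3CCN(C)C[C@H]3O)c2o1`: 16%
Compound 4 `CCOC(=O)N1CCN(Cc2c(O)c([C@H]3CCN(C)C[C@H]3O)c3oc(C)cc(=O)c3c2O)CC1`: not yet measured

All of these values come from a functional assay on MIA PaCa-2 cells (Homo sapiens) for inhibition, read by MTT assay, with a stated time of 48 h, tested at 10 uM; a higher number here means more inhibition of growth at the concentration tested, a lower number less inhibition of growth. Compound 2 stands highest of the three measured compounds at 27%, and its gaps to compound 3 and compound 1 both lie beyond the usual scatter. For the measured compounds named here, all three values are low, however, so no compound here shows strong inhibition of growth at the concentration tested.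

Compound 4 keeps the shared core of compound 2 and changes only the amine: 4-(ethoxycarbonyl)piperazin-1-yl in place of diethylamino on a saturated chain carbon bound to an aromatic carbon. Going by the values given here, no measured compound carries this group, so the evidence is indirect. Compound 2 gives 27%, while compound 3, which also has a ring in that place, gives 16%. On that single comparison, a small downward step is expected in this assay, probably within the scatter. The estimated change is a number 7 percentage points lower from compound 2 to compound 4 (within the scatter). Compound 4 is expected to give about 20%, with an estimated range of 8% to 35%.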

Compound 4, percent growth inhibition at one concentration: 4%
The estimate for compound 4 lay 16 percentage points above the measured number; the measured number lies below the stated range.
By their numbers in this assay, from the lowest: compounds 4, 1 and 3 (each within the scatter of the next, the first and the last beyond it); then compound 2.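

In this assay, for the compounds shown here, putting 4-(ethoxycarbonyl)piperazin-1-yl in place of diethylamino on a saturated chain carbon bound to an aromatic carbon gives a number 23 percentage points lower from compound 2 to compound 4 (beyond the scatter) as the first step in this set that changes one place only. It shows that the amine at this position bears on growth inhibition at the concentration tested, and that here the group with the ring and the ethoxycarbonyl goes with the lower number. Nothing given here accounts for this drop.

The compounds shown leave open whether the ring or the ethoxycarbonyl goes with the lower number. An unsubstituted piperazin-1-yl, a morpholin-4-yl or a dimethylamino group at this position could separate these parts.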